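A few compounds are considered here, and "the series" means these few. Any claim that something is new, unique, unknown or untested is made for them only; others in the source may bear on it.

Within the data shown here, compound 3 `CC(C)[C@H](NC(=O)c1cc(Cl)ccc1O)C(=O)Nc1ccc(C(F)(F)F)cc1` gives 7300 nM in a functional assay on MCF7 cells (Homo sapiens) for cytotoxicity, with a stated time of 72 h (on this read-out higher numbers stand for weaker inhibition and lower numbers for stronger inhibition), the only actual number among the three compounds measured. Compound 1 `CC(C)[C@H](NC(=O)c1cc(Cl)ccc1O)C(=O)Nc1ccc(Cl)c(Cl)c1` reaches only the limit of > 10000 nM in this assay. Compound 2 `COc1ccc(NC(=O)[C@@H](NC(=O)c2cc(Cl)ccc2O)C(C)C)cc1` likewise gives the limit > 10000 nM. Compound 4 `CC(C)[C@H](NC(=O)c1cc(Cl)ccc1O)C(=O)Nc1ccccc1` differs from compound 3 by hydrogen in place of trifluoromethyl on an aromatic carbon. Among the measured compounds shown here, two measured steps bear on this change: a step that the two limits leave unreadable from compound 1 to compound 2, which the limit of > 10000 nM in this assay, at which 2 of the 3 values shown sit, leaves unreadable, and an at least 1.3-fold lower number from compound 2 to compound 3 (0.13 log units; that floor lies within the scatter), a floor that sits within the scatter. With no readable step on the aromatic carbon para to a large group, compound 4 is expected to move no further than the scatter allows, if anything toward weaker inhibition, so a step of a 1.2-fold higher number from compound 3 to compound 4 (0.09 log units; within the scatter) is expected. Compound 4 is therefore estimated at 9000 nM, between 4000 nM and 20000 nM.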

Compound 4, half-maximal inhibitory concentration: > 10000 nM
Compound 4: a limit, no number; the forecaster's own chance of this, stated with the estimate: 55%; at least 1.1-fold (0.04 log units) between middle value and limit.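

In this assay compound 4 gives > 10000 nM, which is a limit and not a number. Hydrogen in place of trifluoromethyl, on an aromatic carbon para to a large group, gives an at least 1.3-fold higher number from compound 3 to compound 4 (0.13 log units; that floor lies within the scatter), so even this floor does not separate the two groups beyond the scatter, and what the trifluoromethyl group contributes remains unproven. The steps linking compound 4 with the other two compounds cannot be read: the limit of > 10000 nM in this assay, at which 3 of the 4 values shown sit.

Going by these compounds, whether an amine or a nitrile on this carbon would give an actual number remains open. So does the true size of the step from trifluoromethyl to hydrogen.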